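The source may hold more compounds than are shown below. What is called first, only, known or untested is meant among the compounds shown, and "the series" means these compounds.

Measured so far:
compound 1 `C=CCc1ccc(OCc2cn(-c3ccccc3CO)nn2)c(O)c1` — 40.4%
compound 2 `C=CCc1ccc(OCc2cn(-c3cccc(C#N)c3)nn2)c(O)c1` — 33.4%
compound 3 `C=CCc1ccc(OCc2cn(-c3ccc(C(=O)c4ccccc4)cc3)nn2)c(O)c1` — 35.6%

In a functional assay on MCF7 cells (Homo sapiens) for inhibition, read by MTT assay, with a stated time of 72 h, tested at 50 uM (on this read-out higher numbers stand for more inhibition of growth at the one concentration tested and lower numbers for less inhibition of growth), compound 3 gives 35.6% and stands second highest of the three numbers, yet compound 2 with 33.4% and compound 1 with 40.4% both lie within the scatter of it, so the three measured compounds are not separable on this read-out.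

Compound 4 `C=CCc1ccc(OCc2cn(-c3ccc(Br)cc3)nn2)c(O)c1` has not been measured. It differs from compound 3 by bromo in place of benzoyl on an aromatic carbon.

Among the compounds with values here, the only measured step, a number 7 percentage points lower from compound 1 to compound 2 (within the scatter), changes the substituent on the aromatic nitrogen, not the aromatic carbon para to a large group, and it stays within the scatter. Within the data shown here, no measured pair bears directly on bromo in place of benzoyl at that position. With all three numbers so close, the working expectation is that compound 4 lands near compound 3, a step of a number 0.4 percentage points higher from compound 3 to compound 4 (within the scatter), that is, none beyond the scatter.

Estimated for compound 4: 36%, range 22% to 50%.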

Compound 4, percent growth inhibition at one concentration: 29.1%
Compound 4: middle estimate off by 6.9 percentage points, on the high side; low and high end bracket the measured number.
By their numbers in this assay, from the lowest: compounds 4, 2, 3 and 1 (each within the scatter of the next, the first and the last beyond it).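

In this assay, bromo in place of benzoyl on the aromatic carbon takes away a whole six-membered aromatic ring and the carbonyl, yet the outcome is a number 6.5 percentage points lower from compound 3 to compound 4 (within the scatter) and this position shows no separable difference between the large group and the single atom. Compared across the aromatic nitrogen, the outcome is a number 4.3 percentage points lower from compound 2 to compound 4 (within the scatter) for 4-bromophenyl in place of 3-cyanophenyl, whereas a number 11.3 percentage points lower from compound 1 to compound 4 (beyond the scatter) gives the series its first modest separation, between 2-(hydroxymethyl)phenyl and 4-bromophenyl. No supporting measurement gives a reason for any of these steps.

From the compounds shown here alone, whether an amine, a carboxylic acid or a longer chain on that aromatic carbon would move the number beyond the scatter remains open. Also open, going by these compounds, is whether the separation follows the hydroxymethyl group itself or the place it occupies, as 2-(hydroxymethyl)phenyl and 4-bromophenyl differ in both.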